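Ring size on the thioether arm: cyclohexyl to cyclopropyl

The compounds below may be only part of what the source reports. "The series", "measured", "known", "first", "only" and "open" are said of these compounds alone.

Among the measured compounds shown here, compound 1 `Cc1cc(N2CC[C@@H](C)[C@@H](N(C)c3ncnc4[nH]ccc34)C2)n2nc(SCC3CCCCC3)nc2n1` carries a (cyclohexylmethyl)sulfanyl group on the shared core and in a functional assay on HGC-27 cells (Homo sapiens) for inhibition, read by MTT assay, with a stated time of 72 h (a lower number here means a stronger inhibitor, a higher number a weaker inhibitor), compound 1 gives 11500 nM, the only number among the two values shown. Compound 2 `CCc1cc(N2CC[C@@H](C)[C@@H](N(C)c3ncnc4[nH]ccc34)C2)n2ncnc2n1` gives in this assay > 100000 nM, which is a limit of the assay rather than a number. Compound 3 `Cc1cc(N2CC[C@@H](C)[C@@H](N(C)c3ncnc4[nH]ccc34)C2)n2nc(SCC3CC3)nc2n1` differs from compound 1 by cyclopropyl in place of cyclohexyl on a saturated chain carbon bound to a sulfur. For the measured compounds named here, no measured step covers this change, so a modest loss beyond the scatter is expected, with a real chance of a limit. Compound 3 is estimated at 22000 nM in this assay, between 6000 nM and 80000 nM, a step of a 1.9-fold higher number from compound 1 to compound 3 (0.28 log units; within the scatter) from compound 1.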

Compound 3, half-maximal inhibitory concentration: 21400 nM
The estimate for compound 3 lay 1.0-fold (0.01 log units) above the measured number; low and high end bracket the measured number.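

In this assay, replacing cyclohexyl with cyclopropyl on the saturated chain carbon bound to a sulfur gives a 1.9-fold higher number from compound 1 to compound 3 (0.27 log units; within the scatter), so this read-out does not separate the two rings at this place. Both compounds with a thioether arm give numbers here. Compound 2 has no such arm, differs in a second place, and stands at a limit of the assay rather than a number: the limit of > 100000 nM in this assay, at which 1 of the 3 values shown sits.

The contribution of the thioether arm itself remains unread. Also open, going by these compounds, is how an arm ending in an amine, a carboxylic acid or a phenyl ring would read.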